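The source may hold more compounds than are shown below. What is called first, only, known or untested is meant among the compounds shown, and "the series" means these compounds.

Measured so far:
- compound 1 `COCc1cc(OC)c(-c2cccc3c(N(CC4CCOCC4)CC4CC4)c(C)nn23)c(OC)c1`: 110 mL.min-1.g-1
- compound 2 `CCc1nn2c(-c3c(OC)cc(C)cc3OC)cccc2c1N(CC1CCOCC1)CC1CC1`: 440 mL.min-1.g-1

In an in vitro ADME assay on microsomes from liver (Homo sapiens) for metabolic stability, with a stated time of 15 min (a lower number here means slower removal, a higher number faster removal of the compound), compound 2 stands highest of the two at 440 mL.min-1.g-1, while compound 1 gives 110 mL.min-1.g-1. The gap between these two compounds lies beyond the scatter. Compound 3 `CCOCc1cc(OC)c(-c2cccc3c(N(CC4CCOCC4)CC4CC4)c(CC)nn23)c(OC)c1` is unmeasured and differs from compound 2 by ethoxy in place of hydrogen on a saturated chain carbon bound to an aromatic carbon. Among the measured compounds shown here, no measured step covers this change, so the expectation is weakly founded. A modest downward move is expected, an estimated 1.8-fold lower number from compound 2 to compound 3 (0.25 log units; within the scatter) that may not clear the scatter. The estimate for compound 3 is 250 mL.min-1.g-1 (100 mL.min-1.g-1 to 600 mL.min-1.g-1).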

Compound 3, intrinsic clearance in microsomes: 520 mL.min-1.g-1
For compound 3 the middle estimate is 2.1-fold (0.32 log units) below the measured one; low and high end bracket the measured number.
By their numbers in this assay, from the lowest: compound 1; then compounds 2 and 3 (each within the scatter of the next).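

In this assay the change from methyl to ethoxymethyl on this saturated chain carbon bound to an aromatic carbon reads as a 1.2-fold higher number from compound 2 to compound 3 (0.07 log units; within the scatter) and leaves compound 2 and compound 3 indistinguishable. In this single pair, the position takes ethoxy in place of hydrogen with no step beyond the scatter. No evidence on the cause of this result is at hand.

Going by these compounds, whether an amine or a carboxylic acid on the same carbon would give a step beyond the scatter stays open. Compound 1 differs from compound 2 in two places, so neither place can be credited alone with the gap between them.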